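The compounds below may be only part of what the source reports. "The series", "measured", "known", "first", "only" and "open" are said of these compounds alone.

Of the compounds shown here, three have been measured so far in an ADME assay on cells (Erythrocyte, Homo sapiens), read by hemolysis, with a stated time of 1 h; a higher number here means a weaker inhibitor, a lower number a stronger inhibitor: compound 1 (`CC(=NNC(=S)Nc1ccccc1F)c1ccccn1`), compound 2 (`CC(=NNC(=S)Nc1cccc([N+](=O)[O-])c1)c1ccccn1`) and compound 3 (`CC(=NNC(=S)Nc1ccccc1[N+](=O)[O-])c1ccccn1`). Compound 1 gives > 10000 nM, which is a limit of the assay and not a number. Compound 2 gives > 10000 nM, again a limit. Compound 3 gives > 10000 nM, also a limit, so it has no exact position on the scale, and neither do the other two compounds.

Compound 4 (`CC(=NNC(=S)Nc1ccccc1)c1ccccn1`) has not yet been measured. It differs from compound 3 in one place, with hydrogen in place of nitro on an aromatic carbon. The closest measured change is at an aromatic carbon too, with nitro in place of fluoro, but a step that the two limits leave unreadable from compound 1 to compound 3 gives no size to carry over. Among the measured compounds shown here, the only guide is the limit of > 10000 nM in this assay, at which 3 of the 3 values shown sit. On that basis, no step beyond the scatter is expected in this assay, in either direction, and compound 4 will most likely report a limit as well. The expected step is a step that the limit leaves unreadable from compound 3 to compound 4, an estimate resting on limits alone. For compound 4 the estimated value is 15000 nM, with an expected range from 8000 nM to 50000 nM.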

Compound 4, half-maximal inhibitory concentration: > 10000 nM
Compound 4 ended at the assay's limit; the forecaster's own chance of this, stated with the estimate: 85%; the middle value lies beyond the limit too.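

In this assay compound 4 gives > 10000 nM, which is a limit of the assay and not a number. Among the compounds shown here, no step from compound 1, compound 2 or compound 3 to compound 4 can therefore be read. The compounds shown leave open how any of the four would rank on a numerical scale, because none has an exact value: the limit of > 10000 nM in this assay, at which 4 of the 4 values shown sit.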